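Aryl urea series: ethoxycarbonyl in place of fluoro

The source may report more compounds than this note shows. Statements on the series, on what has been measured and on what is new or still open speak of the compounds shown alone.

compound 1 `N#CC1CN1C(=O)Nc1ccc(Cl)c(Cl)c1`: 7500 nM
compound 2 `N#CC1CN1C(=O)Nc1ccc(F)cc1`: 6200 nM
compound 3 `CC(C)(C)NC(=O)N1CC1C#N`: 180000 nM

In a functional assay on A549 cells (Homo sapiens) for inhibition (on this read-out higher numbers stand for weaker inhibition and lower numbers for stronger inhibition), compound 2 shows the lowest of the three numbers. Its gap to compound 1 lies within the scatter, so no order between these two can be read; compound 3 stands well beyond the scatter with a much higher number. Compound 4 `CCOC(=O)c1ccc(NC(=O)N2CC2C#N)cc1` has not been measured in this assay. It differs from compound 2 by ethoxycarbonyl in place of fluoro on an aromatic carbon. Going by the values given here, no step between measured compounds covers such an exchange, and the only variation on the aromatic ring among measured compounds leaves the numbers within the scatter of each other. The expected 1.3-fold higher number from compound 2 to compound 4 (0.11 log units; within the scatter) therefore amounts to nothing beyond the scatter, in no settled direction. Compound 4 is estimated at 8000 nM, in a range from 2000 nM to 32000 nM.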

Compound 4, half-maximal inhibitory concentration: 2900 nM
Estimate against measurement, compound 4: 2.8-fold (0.44 log units) above; low and high end bracket the measured number.
By their numbers in this assay, from the lowest: compound 4; then compounds 2 and 1 (each within the scatter of the next); then compound 3.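

On this aromatic carbon, ethoxycarbonyl in place of fluoro gives a 2.1-fold lower number from compound 2 to compound 4 (0.33 log units; beyond the scatter) in this assay. The step is modest, but it shows that this position accepts a group of 5 heavy atoms with no loss of inhibition. No measurement on hand bears on why the number falls. Going by these compounds, it remains open whether the carbonyl or the ethyl part carries the step, which a carboxylic acid, a primary amide or a longer alkyl ester at this carbon would help to separate. An amine here would test a different kind of group.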